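From iodo to methoxy in a growth inhibition series

The source may hold more compounds than are shown below. What is called first, only, known or untested is meant among the compounds shown, and "the series" means these compounds.

Values in a functional assay on RXF 393 cells (Homo sapiens) for inhibition; a higher number here means a weaker inhibitor of growth, a lower number a stronger inhibitor of growth:
- Compound 1 `NC(=O)c1cc(Cl)ccc1NC(=O)COc1ccccc1`: 3930 nM
- Compound 2 `NC(=O)c1cc(I)ccc1NC(=O)COc1ccccc1`: 413 nM
- Compound 3 `COc1ccc(NC(=O)COc2ccccc2)c(C(N)=O)c1`: not yet measured

Compound 2 holds the lower of the two numbers in this assay. Compound 3 carries methoxy in place of iodo on an aromatic carbon. Among the compounds with values here, one measured step bears on this change, a 9.5-fold lower number from compound 1 to compound 2 (0.98 log units; beyond the scatter), where iodo replaced chloro. Methoxy was not part of that step, so it is only a rough guide. A step of similar size is expected, towards a higher number, and the estimated step is a 6.1-fold higher number from compound 2 to compound 3 (0.78 log units; beyond the scatter). For compound 3 the expected value is 2500 nM, with an estimated range of 700 nM to 9000 nM.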

Compound 3, concentration for 50% growth inhibition: 1400 nM
Beside the measured number, compound 3's estimate is 1.8-fold (0.25 log units) above it; the measured number falls inside the stated range.
By their numbers in this assay, from the lowest: compound 2; then compound 3; then compound 1.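

Methoxy on this aromatic carbon gives a 3.4-fold higher number from compound 2 to compound 3 (0.53 log units; beyond the scatter) but also a 2.8-fold lower number from compound 1 to compound 3 (0.45 log units; beyond the scatter) in this assay so a group that is not a halogen lands inside the span set by chloro and iodo. Iodo therefore keeps the lowest number of the three, but a lower number than chloro's does not require a halogen here. Nothing available explains this order. As far as these compounds go, whether an ethoxy group, an amine or a bromo group on the same carbon would match or pass iodo remains open.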